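The compounds below may be only part of what the source reports. "The series", "measured", "known", "first", "only" and "open" are said of these compounds alone.

Compound 1: `NS(=O)(=O)c1cc(-c2nnc(CN3CCN(Cc4ccccc4)CC3)o2)c(Cl)cc1SCc1ccccc1`, in a functional assay on HCT-116 cells (Homo sapiens) for cytotoxicity, read by MTT assay, with a stated time of 72 h (a higher number here means a weaker inhibitor, a lower number a stronger inhibitor), compound 1 gives 26000 nM.
Compound 2: `Cc1ccc(C)c(N2CCN(Cc3nnc(-c4cc(S(N)(=O)=O)c(SCc5ccccc5)cc4Cl)o3)CC2)c1`, compound 2 gives 17000 nM.
Compound 3: `CCOC(=O)c1cn(Cc2nnc(-c3cc(S(N)(=O)=O)c(SCc4ccccc4)cc3Cl)o2)nn1`, compound 3 gives 108000 nM.

Compound 3 stands highest of the three numbers measured; compound 1 is the nearest to it and compound 2 the furthest, both separated from compound 3 by more than the scatter. Compound 4 is `NS(=O)(=O)c1cc(-c2nnc(CNC(=O)c3ccccc3)o2)c(Cl)cc1SCc1ccccc1`, not yet measured. The change from compound 3 to compound 4 is benzamido in place of 4-(ethoxycarbonyl)-1H-1,2,3-triazol-1-yl on a saturated chain carbon bound to an aromatic carbon. Going by the values given here, only one measured step exists, a 1.5-fold lower number from compound 1 to compound 2 (0.18 log units; within the scatter), and it exchanges one substituent on an amine nitrogen in a ring for another; it does not touch the same part of the molecule as the change to compound 4 and so bears on it only loosely. What the three values show is that the two compounds with an amine-bearing ring at that position lie lower than compound 3. Compound 4 is therefore expected to give a number lower than compound 3, by an estimated 2.7-fold lower number from compound 3 to compound 4 (0.43 log units; beyond the scatter), landing nearer to compound 1 than to compound 3. The estimate for compound 4 is 40000 nM, with a range from 15000 nM to 110000 nM.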

Compound 4, half-maximal inhibitory concentration: 42000 nM
Compound 4: the middle estimate sits 1.1-fold (0.02 log units) below what was measured, within the range that was stated.
By their numbers in this assay, from the lowest: compounds 2, 1 and 4 (each within the scatter of the next, the first and the last beyond it); then compound 3.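

In this assay, benzamido in place of 4-(ethoxycarbonyl)-1H-1,2,3-triazol-1-yl on a saturated chain carbon bound to an aromatic carbon gives a 2.6-fold lower number from compound 3 to compound 4 (0.41 log units; beyond the scatter), the first step shown at this place, as the earlier step changed only a substituent on an amine nitrogen in a ring. Compound 4 carries no amine-bearing ring at this place, so among these compounds a number lower than that of compound 3 does not depend on such a ring. No measurement shown accounts for this step.

The compounds shown leave open whether the step follows the amide or the benzene ring of benzamido, which an acetamido or a benzylamino group at the same place would separate. They also leave open the role of the ester of compound 3, which a carboxylic acid there would test.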